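A few compounds are considered here, and "the series" means these few. Any claim that something is new, unique, unknown or untested is made for them only; others in the source may bear on it.

Measured compounds:
compound 1 `CCc1ccc(Nc2cc(NC(=O)Nc3cc(OC)cc(OC)c3)ncn2)cc1` — 32.7%
compound 2 `COc1cc(NC(=O)Nc2cc(Nc3cc(Br)ccc3OC)ncn2)cc(OC)c1` — 23.1%

In a functional assay on NCI-H1581 cells (Homo sapiens) for inhibition, read by MTT assay, with a stated time of 48 h, tested at 10 uM (on this read-out lower numbers stand for less inhibition and higher numbers for more inhibition at the one concentration tested (going by the name of the read-out)), compound 1 gives 32.7% and compound 2 gives 23.1%. Within the data shown here, on paper compound 2 holds the smaller of the two figures, but the only measured step, a number 9.6 percentage points lower from compound 1 to compound 2 (within the scatter), is within the scatter, so the two compounds are not separated by this assay.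

Compound 3 `COc1cc(NC(=O)Nc2cc(Nc3ccc(OC)c(I)c3)ncn2)cc(OC)c1` has not yet been measured. It differs from compound 2 by 3-iodo-4-methoxyphenyl in place of 5-bromo-2-methoxyphenyl on a nitrogen on an aromatic ring. Among the measured compounds shown here, the one step that bears on it, a number 9.6 percentage points lower from compound 1 to compound 2 (within the scatter), also exchanged the group on that nitrogen and produced no change beyond the scatter, so nothing beyond the scatter is expected here either. Compound 3 is therefore estimated at 25%, within 8% to 42%, an expected step of a number 1.9 percentage points higher from compound 2 to compound 3 (within the scatter).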

Compound 3, a percentage reported as inhibition, at one concentration (the size of the read-out at that concentration, not a potency): 43%
Compound 3: middle estimate off by 18 percentage points, on the low side; the measured number lies above the stated range.
By their numbers in this assay, from the lowest: compounds 2 and 1 (each within the scatter of the next); then compound 3.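

In this assay, the group on a nitrogen on an aromatic ring now moves the read-out beyond the scatter: 3-iodo-4-methoxyphenyl in place of 5-bromo-2-methoxyphenyl gives a number 19.9 percentage points higher from compound 2 to compound 3 (beyond the scatter), a modest step, whereas the earlier exchange at this place did not separate its two compounds. The same entering group in place of 4-ethylphenyl gives a number 10.3 percentage points higher from compound 1 to compound 3 (beyond the scatter), also modest, so compound 3 stands apart from both other compounds. Nothing available on these compounds bears on why this group differs from the other two.

The entering and leaving groups differ both in the halogen and in where the substituents sit, so the step cannot be assigned to either difference. As far as these compounds go, a 3-bromo-4-methoxyphenyl group would separate the two, and it remains open how an amine or a carboxylic acid on this ring would read.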